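The compounds below may be only part of what the source reports. "The series", "measured", "known", "first", "only" and "open" are said of these compounds alone.

The measured compounds:

Compound 1 `CC#C[C@@H](Cc1nnn[nH]1)c1ccc(OCc2ccc3scc(-c4ccccc4C(F)(F)F)c3c2)cc1` gives < 0.0667 h in an ADME assay on microsomes from liver (Homo sapiens) for metabolic stability (on this read-out lower numbers stand for a shorter-lived compound and higher numbers for a longer-lived compound), which is a limit of the assay rather than a number.
Compound 2 `CC#C[C@@H](Cc1nnn[nH]1)c1ccc(OCc2ccc3sc(F)c(-c4ccccc4C)c3c2)cc1` gives 0.0667 h in this assay.
Compound 3 `CC#C[C@@H](Cc1nnn[nH]1)c1ccc(OCc2ccc3sc(I)c(-c4ccccc4C)c3c2)cc1` gives 0.167 h in this assay.

Compound 1 stands at the limit of < 0.0667 h in this assay, at which 1 of the 3 values shown sits, so its half-life is known only as a limit and its place among the three cannot be fixed as a number. Within the data shown here, the one measured step, a 2.5-fold higher number from compound 2 to compound 3 (0.40 log units; beyond the scatter), concerns iodo in place of fluoro and does not touch the group that changes between compound 1 and compound 4. Compound 4 `CC#C[C@@H](Cc1nnn[nH]1)c1ccc(OCc2ccc3scc(C4CCCCC4)c3c2)cc1` differs from compound 1 by cyclohexyl in place of 2-(trifluoromethyl)phenyl on an aromatic carbon. Among the measured compounds shown here, no measured step bears on this change, so the data give no ground for a step beyond the scatter in either direction. The step that the limit leaves unreadable from compound 1 to compound 4 is therefore expected to stay small. Compound 4 is estimated at 0.06 h, within the range 0.03 h to 0.17 h, with a fair chance that the assay again reports only a limit.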

Compound 4, half-life: 0.183 h
Compound 4: middle estimate off by 3.1-fold (0.48 log units), on the low side, and the stated range ends below it.
By their numbers in this assay, from the lowest: compound 2; then compounds 3 and 4 (each within the scatter of the next).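

Among these compounds, until now, this position, on an aromatic carbon two ring bonds from the ring sulfur, had carried only six-membered aromatic rings, so compound 4 gives the first reading with a non-aromatic ring there. Replacing 2-(trifluoromethyl)phenyl with cyclohexyl gives an at least 2.7-fold higher number from compound 1 to compound 4 (0.43 log units; beyond the scatter), which shows that the half-life in this assay responds to the group at this position and that an aromatic ring is not needed there for the higher number. The size of this step has only a lower bound, since the value for compound 1 is a limit of the assay and not a number: the limit of < 0.0667 h in this assay, at which 1 of the 4 values shown sits.

This single change removes the trifluoromethyl group and the aromatic ring together, so the compounds shown cannot say which of the two matters. As far as these compounds go, whether a plain phenyl, a cyclopentyl or a piperidine ring at this position would follow cyclohexyl also remains open.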